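Swapping trifluoromethyl for fluoro on the aryl ring

The compounds below may be only part of what the source reports. "The series", "measured", "known", "first", "only" and "open" are said of these compounds alone.

Compound 1 `CC1=C(/C=C/C(=O)/C=C/c2cccc(C(F)(F)F)c2)C(C)(C)CCC1` and compound 2 `CC1=C(/C=C/C(=O)/C=C/c2cc(C(F)(F)F)cc(C(F)(F)F)c2)C(C)(C)CCC1` share a core and differ only on the aromatic ring. In a functional assay on PC-3 cells (Homo sapiens) for cytotoxicity, read by MTT assay, with a stated time of 72 h (on this read-out lower numbers stand for stronger inhibition and higher numbers for weaker inhibition), compound 1 gives 7700 nM, and compound 2 gives 7200 nM. Of the two numbers, compound 1 has the higher one, though the gap is small: a 1.1-fold lower number from compound 1 to compound 2 (0.03 log units; within the scatter). Compound 3 `CC1=C(/C=C/C(=O)/C=C/c2cccc(F)c2)C(C)(C)CCC1` is the next step from compound 1: fluoro in place of trifluoromethyl on an aromatic carbon, on an aromatic carbon meta to a large group. Among the compounds with values here, only the step from compound 1 to compound 2 bears on this change, and it concerns a second trifluoromethyl rather than the fate of the first, so it is at best a loose guide; its size stayed within the scatter. Compound 3 is therefore expected to show a step of about a 1.0-fold higher number from compound 1 to compound 3 (0.02 log units; within the scatter) in this assay, that is, no change beyond the scatter. Compound 3 is estimated at 8000 nM, with a range from 3000 nM to 20000 nM.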

Compound 3, half-maximal inhibitory concentration: 18700 nM
The estimate for compound 3 lay 2.3-fold (0.37 log units) below the measured number; measured number inside the range.
By their numbers in this assay, from the lowest: compounds 2 and 1 (each within the scatter of the next); then compound 3.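

The trifluoromethyl already present on the ring turns out to count in this assay: replacing it with fluoro brings a 2.4-fold higher number from compound 1 to compound 3 (0.39 log units; beyond the scatter), a modest step but one beyond the scatter. The earlier comparison showed only that adding a second trifluoromethyl brings a 1.1-fold lower number from compound 1 to compound 2 (0.03 log units; within the scatter), which stays within the scatter, so it said nothing about replacing the first. No measurement offered here accounts for the rise in the number with fluoro at this position.

As far as these compounds go, it remains open whether another group on the same aromatic carbon, such as a methoxy group, a nitrile or an amine, would hold the number near that of compound 1 or shift it as fluoro does. Whether the same swap would give a similar step on compound 2, which carries two trifluoromethyl groups, is also unsettled.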